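Swapping chlorophenyl for pyrimidinyl on an inactive sulfonamide

A few compounds are considered here, and "the series" means these few. Any claim that something is new, unique, unknown or untested is made for them only; others in the source may bear on it.

Compound 2 `O=C(Nc1ccc(S(=O)(=O)Nc2ccc(Cl)cc2)cc1)c1ccc(Cl)cc1Cl` was tested in a functional assay on HEK293 cells for agonist activity at probable G-protein coupled receptor 27 (Homo sapiens), read by a luciferase reporter and beta-arrestin recruitment, with a stated time of 10 min; a lower number here means that less compound is needed, a higher number that more compound is needed for the effect. In this assay compound 2 gives > 100000 nM, which is a limit of the assay rather than a number. Compound 1 `O=C(Nc1ccc(S(=O)(=O)NCc2ccccc2)cc1)c1ccc(Cl)cc1Cl` differs only by a benzyl on the sulfonamide nitrogen. In this assay compound 1 gives > 100000 nM, also a limit. The step that the two limits leave unreadable from compound 1 to compound 2 is therefore unreadable. Compound 3 `O=C(Nc1ccc(S(=O)(=O)Nc2ncccn2)cc1)c1ccc(Cl)cc1Cl` carries the change (pyrimidin-2-yl in place of 4-chlorophenyl on a sulfonamide nitrogen). No readable step bears on it, and both measured values sit at the limit of > 100000 nM in this assay, at which 2 of the 2 values shown sit. Compound 3 is expected to stay at the limit as well, estimated at 100000 nM within 30000 nM to 300000 nM. The step of a number no higher from compound 2 to compound 3 (the limit leaves the size open) is thus expected to be none beyond the scatter.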

Compound 3, half-maximal effective concentration: > 100000 nM
Compound 3 gave a limit, no number (the forecaster's own chance of this, stated with the estimate: 85%); the middle value sits exactly at the limit.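

Compound 3 also stops at a limit, > 100000 nM in this assay, and its steps from compound 1 and compound 2 cannot be read. The compounds shown leave open whether any group on the sulfonamide nitrogen gives a measurable value in this assay.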